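Removing a Methyl Group on Two Related Cores

A few compounds are considered here, and "the series" means these few. Any claim that something is new, unique, unknown or untested is made for them only; others in the source may bear on it.

Compound 1 `Cc1cnn(C(=O)N(C)CCN(C)Cc2ccc(OCc3ccccc3)cc2)c1` and compound 2 `CN(CCN(C)C(=O)n1cccn1)Cc1ccc(OCc2ccccc2)cc1` share one core. In an assay on membranes from brain for binding affinity to Monoglyceride lipase (Mus musculus), read by fluorescence, with stated times of 1 h and 30 min (on this read-out higher numbers stand for weaker inhibition and lower numbers for stronger inhibition), compound 1 gives 1200 nM, and compound 2 gives 660 nM. For the measured compounds named here, the single change between them, (hydrogen in place of methyl on an aromatic carbon), gave a 1.8-fold lower number from compound 1 to compound 2 (0.26 log units; within the scatter). Compound 3 `Cc1cnn(C(=O)NCc2ccc(OC(c3ccccc3)c3ccccc3)cc2)c1` is built on a different core; the difference between the two cores is not broken down here. For compound 3 this assay reports only a limit, > 100000 nM, which is the limit of > 100000 nM in this assay, at which 1 of the 3 values shown sits. Compound 4 `O=C(NCc1ccc(OC(c2ccccc2)c2ccccc2)cc1)n1cccn1` carries the same change as before, (hydrogen in place of methyl on an aromatic carbon), at the same place. Because that change gave a 1.8-fold lower number from compound 1 to compound 2 (0.26 log units; within the scatter), the step in this assay is expected to be similarly small, a number no higher from compound 3 to compound 4 (the limit leaves the size open), so compound 4 would most likely again show up only as a limit. Compound 4 is estimated to give roughly 100000 nM, between 30000 nM and 300000 nM.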

Compound 4, half-maximal inhibitory concentration: > 100000 nM
Compound 4: no number, only a limit (the forecaster's own chance of this, stated with the estimate: 70%); the middle value lies on the limit itself.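

Compound 3 and compound 4 both appear only as limits, so no step between them can be read: the limit of > 100000 nM in this assay, at which 2 of the 4 values shown sit.

The compounds shown leave open whether the change from 4-methyl-1H-pyrazol-1-yl to 1H-pyrazol-1-yl alters inhibition at all on this core.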